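The compounds below may be only part of what the source reports. "The series", "measured", "known", "first", "only" and "open" are said of these compounds alone.

Compound 1 `O=C1Nc2ccccc2/C1=N/NC(=S)Nc1ccccc1`: 3530 nM
Compound 2 `O=C1Nc2ccccc2/C1=N/NC(=S)Nc1ccc(F)cc1`: 14200 nM
Compound 3 `CCc1ccc(NC(=S)N/N=C2\C(=O)Nc3ccccc32)cc1`: 4050 nM

In a functional assay on KB 3-1 cells (Homo sapiens) for cytotoxicity, read by MTT assay, with a stated time of 72 h (a lower number here means a stronger inhibitor, a higher number a weaker inhibitor), compound 3 gives 4050 nM, which places it in the lower part of this small set, with a 3.5-fold lower number from compound 2 to compound 3 (0.54 log units; beyond the scatter). Compound 4 `CC(C)c1ccc(NC(=S)N/N=C2\C(=O)Nc3ccccc32)cc1` differs from it by methyl in place of hydrogen on a saturated chain carbon bound to an aromatic carbon and a saturated chain carbon, turning ethyl to isopropyl. The closest measured change, ethyl in place of hydrogen on an aromatic carbon, gave a 1.1-fold higher number from compound 1 to compound 3 (0.06 log units; within the scatter). Fluoro in place of hydrogen gave a 4.0-fold higher number from compound 1 to compound 2 (0.60 log units; beyond the scatter), but that is a different kind of group. No step beyond the scatter is therefore expected in this assay. The estimate is a 1.0-fold higher number from compound 3 to compound 4 (0.02 log units; within the scatter). Compound 4 is expected at 4200 nM, with an estimated range of 1900 nM to 9000 nM.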

Compound 4, half-maximal inhibitory concentration: 9110 nM
Compound 4: middle estimate off by 2.2-fold (0.34 log units), on the low side; measured number above the stated range.
By their numbers in this assay, from the lowest: compounds 1 and 3 (each within the scatter of the next); then compounds 4 and 2 (each within the scatter of the next).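

Turning ethyl to isopropyl gave a step beyond the scatter in this assay, a 2.2-fold higher number from compound 3 to compound 4 (0.35 log units; beyond the scatter), whereas the ethyl group in place of hydrogen had given none. Isopropyl in place of hydrogen on the aromatic carbon also gave a step beyond the scatter, a 2.6-fold higher number from compound 1 to compound 4 (0.41 log units; beyond the scatter), so fluoro is no longer the only group shown to do so. Isopropyl and fluoro themselves remain unseparated, a 1.6-fold lower number from compound 2 to compound 4 (0.19 log units; within the scatter). Nothing available explains these steps. From the compounds shown here alone, whether a tert-butyl group, a longer chain or a methoxy group would continue this trend remains open.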